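The source may report more compounds than this note shows. Statements on the series, on what has been measured and on what is new or still open speak of the compounds shown alone.

Series notes. In an ADME assay on microsomes from liver (Homo sapiens) for metabolic stability, tested at 2.5 uM (a lower number here means slower removal, a higher number faster removal of the compound), compound 1 `Clc1ccc(-c2ccc(Cn3nnc4ccccc43)cn2)cc1` gives 0.2 mL/min/g, compound 2 `Brc1cccc2c1nnn2Cc1ccccc1` gives 4.7 mL/min/g and compound 3 `Fc1ccc(Cn2nnc3c(Br)cccc32)cc1` gives 1.2 mL/min/g. Compound 3 thus stands second highest of the three numbers, below compound 2 and above compound 1. Going by the values given here, the only measured step, a 3.9-fold lower number from compound 2 to compound 3 (0.59 log units; beyond the scatter), concerns a different change and bears only loosely on a halogen swap. Compound 4 `Clc1ccc(Cn2nnc3c(Br)cccc32)cc1` differs from compound 3 by chloro in place of fluoro on an aromatic carbon. Compound 1 also carries a chloro on a six-membered ring, yet it differs from compound 3 in several places, so its value is no guide. A number close to compound 3 is therefore expected, and compound 4 is estimated at 1.5 mL/min/g, within 0.6 mL/min/g to 4 mL/min/g. The step of a 1.3-fold higher number from compound 3 to compound 4 (0.10 log units; within the scatter) that this estimate means is expected to lie within the scatter.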

Compound 4, intrinsic clearance in a liver preparation (reported as CLH), per the amount of preparation that the assay uses: 0.6 mL/min/g
Compound 4: middle estimate off by 2.5-fold (0.40 log units), on the high side; low and high end bracket the measured number.
By their numbers in this assay, from the lowest: compound 1; then compounds 4 and 3 (each within the scatter of the next); then compound 2.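

In this assay the swap gives a 2.0-fold lower number from compound 3 to compound 4 (0.30 log units; within the scatter) and so chloro and fluoro cannot be told apart on this aromatic carbon, para to a large group. Against the unsubstituted ring of compound 2, chloro gives a 7.8-fold lower number from compound 2 to compound 4 (0.89 log units; beyond the scatter) and so the step beyond the scatter from hydrogen is no longer seen with fluoro alone. Nothing at hand gives a reason for either step. Open, on these data alone, is whether a methoxy group or an amine at this place would stay near these numbers, or whether the step from hydrogen is confined to halogens.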